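Losing the 2-ethoxyethyl group

This account rests on a few compounds, and the source may have more. Where it says the series, first, only, none or still open, it means among the compounds named here.

Within the data shown here, in a functional assay on the whole organism with Rattus norvegicus as the target (on this read-out lower numbers stand for an effect already at smaller amounts and higher numbers for an effect only at larger amounts of compound), compound 1 `CCOCCOC(=O)C(=O)Nc1nc(-c2cc(OC)no2)cs1` gives 11 mg/kg, while compound 2 `CCOCCOC(=O)C(=O)Nc1nc(-c2cc(C)on2)cs1` gives 2 mg/kg, the lower of the two numbers so far. Among the measured compounds shown here, the only measured step is a 5.5-fold lower number from compound 1 to compound 2 (0.74 log units; beyond the scatter), and it places 5-methyl-1,2-oxazol-3-yl where 3-methoxy-1,2-oxazol-5-yl stood on an aromatic carbon.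

Compound 3 `Cc1cc(-c2csc(NC(=O)C(=O)O)n2)no1` keeps the 5-methyl-1,2-oxazol-3-yl group of compound 2 and differs elsewhere: hydrogen in place of 2-ethoxyethyl on an oxygen next to a carbonyl group. This puts hydrogen in place of 2-ethoxyethyl on an oxygen next to a carbonyl group. For the measured compounds named here, no measured step touches that place, so the data give neither a direct size nor a direction for this change. Going by the values given here, the one available yardstick is the step between compound 1 and compound 2, a 5.5-fold lower number from compound 1 to compound 2 (0.74 log units; beyond the scatter), which shows only that a single change in these two compounds can exceed the scatter. The central expectation is therefore a small change, with a step of similar size possible in either direction. The estimated change is a 1.5-fold higher number from compound 2 to compound 3 (0.18 log units; within the scatter). For compound 3 the expected value is 3 mg/kg, with an estimated range from 0.6 mg/kg to 15 mg/kg.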

Compound 3, dose for half-maximal effect: 17 mg/kg
For compound 3 the middle estimate is 5.7-fold (0.75 log units) below the measured one, and the stated range ends below it.
By their numbers in this assay, from the lowest: compound 2; then compounds 1 and 3 (each within the scatter of the next).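

At this position a change now has a measured size: in this assay, hydrogen in place of 2-ethoxyethyl on an oxygen next to a carbonyl group gives an 8.5-fold higher number from compound 2 to compound 3 (0.93 log units; beyond the scatter). The earlier compounds shown here carried the 2-ethoxyethyl group throughout and so showed only that the other place in the molecule matters; with the 5-methyl-1,2-oxazol-3-yl group held fixed, this step shows that the group on this oxygen also moves the number beyond the scatter, and that in this pair the lower number belongs to the compound that keeps 2-ethoxyethyl. No measurement at hand bears on why the number rises when the 2-ethoxyethyl group is lost.

The compounds shown give only the two extremes at this oxygen, the full 2-ethoxyethyl group and hydrogen, so they leave open whether a plain ethyl group there, or a longer chain, would stay close to compound 2 or move towards compound 3. They also leave open whether the same exchange would give a step of similar size on a compound carrying 3-methoxy-1,2-oxazol-5-yl.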